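A few compounds are considered here, and "the series" means these few. Any claim that something is new, unique, unknown or untested is made for them only; others in the source may bear on it.

Working notes on the series. In a functional assay on HCT-116 cells (Homo sapiens) for cytotoxicity, read by MTT assay, with a stated time of 2 days, tested at 10 uM (a lower number here means less inhibition, a higher number more inhibition at the concentration tested (going by the name of the read-out)), compound 3 `CCCCNc1nc(NCc2ccco2)c2cc(F)ccc2n1` gives 87.8%. Compound 1 `CCCCNc1nc(NCc2ccco2)c2ccccc2n1` gives 94.8% in this assay. The two differ in one place, (hydrogen in place of fluoro on an aromatic carbon), and the step recorded is a number 7 percentage points higher from compound 3 to compound 1 (within the scatter). Compound 2 `Fc1ccc2nc(NCCCCN3CCN(c4cccc(Cl)c4Cl)CC3)nc(NCc3ccco3)c2c1` gives 97.1% in this assay; the difference between its core and that of compound 3 is not broken down here. Compound 4 `Clc1cccc(N2CCN(CCCCNc3nc(NCc4ccco4)c4ccccc4n3)CC2)c1Cl` awaits this assay. It differs from compound 2 by hydrogen in place of fluoro on an aromatic carbon, the same change seen before, at a place described in the same words. Going by the values given here, only one precedent exists, so the step expected from compound 2 onward is a number 1.1 percentage points lower from compound 2 to compound 4 (within the scatter), set beside a number 7 percentage points higher from compound 3 to compound 1 (within the scatter) and kept small because compound 2 already gives 97.1%, which leaves little room upward. Compound 4 is therefore expected at 96%, with a range from 88% to 100%.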

Compound 4, a percentage reported as inhibition, at one concentration (the size of the read-out at that concentration, not a potency): 94.7%
Beside the measured number, compound 4's estimate is 1.3 percentage points above it; measured number inside the range.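

In this assay, the new step for hydrogen in place of fluoro on an aromatic carbon is a number 2.4 percentage points lower from compound 2 to compound 4 (within the scatter). Set beside the earlier step on the other core, it does not differ from it: the same change on two cores in this assay, a number 7 percentage points higher (within the scatter) from compound 3 to compound 1 and a number 2.4 percentage points lower (within the scatter) from compound 2 to compound 4, 9.4 percentage points apart, within the scatter of two such steps. Going by these compounds alone, this gives no sign that the change behaves differently from one core to the other, but it does not show that the change is without effect or that it carries over reliably, since only two steps are available, each within the scatter and each read at one concentration, which says nothing about potency.

Still open, on these data alone, is whether another group at this place, such as chloro, methoxy or trifluoromethyl, would give a step beyond the scatter. Also open, as far as these compounds go, is whether the same holds on a core bearing a longer chain at the side-chain position.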